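The source may report more compounds than this note shows. Statements on the series, on what has been measured and on what is new or still open speak of the compounds shown alone.

Measured compounds in a functional assay on the whole organism (Central nervous system) for activation, with Mus musculus as the target; on this read-out higher numbers stand for an effect only at larger amounts of compound and lower numbers for an effect already at smaller amounts:

compound 1 `O=C(CCC(=O)c1cccs1)NCCCO`: 300 mg/kg
compound 2 `O=C1CCC2(c3ccc(F)cc3)OCCCN12`: 75 mg/kg

Of the two compounds measured in this assay, compound 2 stands at the lower number, and the gap to compound 1 lies beyond the usual scatter of repeated measurements, so compound 2 is the more active of the pair on this read-out. Compound 1 is an open-chain compound with a different core, so its value says little about what a single substituent change on the core of compound 2 would do.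

Compound 3 `COc1ccc(C23CCC(=O)N2CCCO3)cc1` keeps the core of compound 2 and differs from it in one place: methoxy in place of fluoro on an aromatic carbon. Among the compounds with values here, no step of this kind between measured compounds is available, so the size and direction of the change can only be estimated. The account expects the step from compound 2 to compound 3 to be small, with no direction beyond the scatter, that is no change at the digits printed from compound 2 to compound 3 (within the scatter). For compound 3 in this assay the expected value is 75 mg/kg, within a range from 30 mg/kg to 200 mg/kg.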

Compound 3, dose for half-maximal effect: < 150 mg/kg
Compound 3 gave a limit, no number; the forecaster's own chance of this, stated with the estimate: 10%; the middle value lies beyond the limit too.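

Compound 3 gave < 150 mg/kg, which is a limit of the assay and not a number. Within the data shown here, no step from compound 2 to compound 3 can therefore be read. The compounds shown leave open whether methoxy in place of fluoro on an aromatic carbon changes the dose needed for half-maximal effect at all, and in which direction.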